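Moving the nitro group within a lactone ester pair

The compounds below may be only part of what the source reports. "The series", "measured", "known", "first", "only" and "open" are said of these compounds alone.

Compound 1 `CN(C)c1ccc(C(=O)OCC2(CO)C/C(=C\c3ccc([N+](=O)[O-])cc3)C(=O)O2)cc1` and compound 2 `CN(C)c1cccc(C(=O)OCC2(CO)C/C(=C\c3cccc([N+](=O)[O-])c3)C(=O)O2)c1` were both tested in an assay on isolated protein for binding affinity to Ras guanyl-releasing protein 3 (Homo sapiens); a lower number here means a stronger inhibitor, a higher number a weaker inhibitor. Compound 1 gives 3.8 nM there, and compound 2 gives 5.3 nM. Compound 2 carries the higher of the two numbers, but its gap to compound 1 lies within the scatter, so no order can be read from them. Compound 3 `CN(C)c1cccc(C(=O)OCC2(CO)C/C(=C\c3ccc([N+](=O)[O-])cc3)C(=O)O2)c1` has not yet been measured. It differs from compound 2 by 4-nitrophenyl in place of 3-nitrophenyl on a double-bonded chain carbon bound to a double-bonded ring carbon; the two share the same atoms, joined differently, and the group that leaves and the group that enters each hold one six-membered aromatic ring of carbon only and two hydrogen-bond acceptors. For the measured compounds named here, no step between measured compounds isolates this change. Compound 1 already carries 4-nitrophenyl, and its value of 3.8 nM sits within the scatter of compound 2. The step of a 1.2-fold lower number from compound 2 to compound 3 (0.07 log units; within the scatter) is therefore expected to stay within the scatter, in no firm direction. Compound 3 is estimated at 4.5 nM, within a range of 2 nM to 10 nM.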

Compound 3, inhibition constant: 2.3 nM
For compound 3 the middle estimate is 2.0-fold (0.29 log units) above the measured one; measured number inside the range.
By their numbers in this assay, from the lowest: compounds 3, 1 and 2 (each within the scatter of the next, the first and the last beyond it).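

In this assay, 4-nitrophenyl in place of 3-nitrophenyl on a double-bonded chain carbon bound to a double-bonded ring carbon gives a 2.3-fold lower number from compound 2 to compound 3 (0.36 log units; beyond the scatter) and so shows, as a modest step, that this position is sensitive to where the nitro group sits. The earlier pair differed in two places and could not isolate this change. The other single change, 3-(dimethylamino)phenyl in place of 4-(dimethylamino)phenyl on a carbonyl carbon, gives a 1.7-fold lower number from compound 1 to compound 3 (0.22 log units; within the scatter) and sets no order between those two compounds. The data shown offer no explanation for either step.

Still open, going by these compounds, is how an amine or a carboxylic acid in place of the nitro group would read in this assay on this phenyl ring. Also open, on these data alone, is whether the step from 3-nitrophenyl to 4-nitrophenyl holds when 4-(dimethylamino)phenyl sits on the carbonyl carbon.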